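The source may hold more compounds than are shown below. What is called first, only, known or untested is meant among the compounds shown, and "the series" means these compounds.

Three compounds that share a core have been run in a physicochemical assay for solubility, in phosphate buffer, measured as kinetic solubility; a higher number here means a more soluble compound, a lower number a less soluble compound. Compound 1 `CC(C)[C@@H](C[C@H]1SC(=O)NC1=O)c1ccc(-c2ccc3cccc(F)c3c2)[nH]c1=O` gives 23900 nM. Compound 2 `CC(C)(/C=C1\OC(=O)NC1=O)c1ccc(-c2ccc3cccc(F)c3c2)[nH]c1=O` gives 36100 nM. Compound 3 `CC(C)C(c1ccc(-c2ccc3cccc(F)c3c2)[nH]c1=O)C1SC(=O)NC1=O` gives 20100 nM, the smallest of the three numbers, though its gaps to compound 1 and to compound 2 both lie within the scatter, so the three compounds stand together. Compound 4 `CC(C)C(CC1C(=O)NC(=O)N1C)c1ccc(-c2ccc3cccc(F)c3c2)[nH]c1=O` has not yet been measured. It differs from compound 3 in one place: (3-methyl-2,5-dioxoimidazolidin-4-yl)methyl in place of 2,4-dioxo-1,3-thiazolidin-5-yl on a saturated chain carbon bound to an aromatic carbon and a saturated chain carbon. Among the compounds with values here, no pair of measured compounds isolates such a change, so the step of a 1.1-fold higher number from compound 3 to compound 4 (0.04 log units; within the scatter) is expected to be small, with no direction beyond the scatter. Compound 4 is therefore expected to give about 22000 nM, within a range from 8000 nM to 55000 nM.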

Compound 4, solubility: 33600 nM
Beside the measured number, compound 4's estimate is 1.5-fold (0.18 log units) below it; measured number inside the range.
By their numbers in this assay, from the lowest: compounds 3, 1, 4 and 2 (each within the scatter of the next).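

In this assay, within the data shown here, the step of a 1.7-fold higher number from compound 3 to compound 4 (0.22 log units; within the scatter) gives the first comparison in this set of compounds that differ in one place. On this saturated chain carbon, (3-methyl-2,5-dioxoimidazolidin-4-yl)methyl can thus replace 2,4-dioxo-1,3-thiazolidin-5-yl without a shift beyond the scatter. Nothing available offers a reason for the size of this step. Still open, as far as these compounds go, is how the number responds to a different kind of group at this position, such as an amine or a carboxylic acid.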